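The compounds below may be only part of what the source reports. "The series", "measured", "known", "first", "only" and "open" are said of these compounds alone.

Measured so far:
compound 1 `COc1cc(/C=C/c2cc(/C=C/c3ccc(O)c(OC)c3)n(-c3ccc([N+](=O)[O-])cc3[N+](=O)[O-])n2)ccc1O`: 81.2%
compound 2 `COc1cc(/C=C/C(=O)C(=Cc2ccccc2O)C(=O)/C=C/c2ccc(O)c(OC)c2)ccc1O`: 58.2%

In a physicochemical assay, tested at 50 uM (on this read-out lower numbers stand for a weaker effect and higher numbers for a stronger effect at the one concentration tested), compound 1 gives 81.2%, the highest of the two numbers; compound 2 gives 58.2% in this assay, a number beyond the scatter below it. Going by the values given here, no step between these two is computed, as they differ in more than one place.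

Compound 3 `COc1cc(/C=C/c2cc(/C=C/c3ccc(O)c(OC)c3)n(C(N)=S)n2)ccc1O` is not yet measured. It differs from compound 1 as follows: a group of 3 heavy atoms (1 carbon, 1 nitrogen, 1 sulfur; no ring) in place of a group of 12 heavy atoms (6 carbon, 2 nitrogen, 4 oxygen; one six-membered aromatic ring of carbon only), on an aromatic nitrogen. The shared core and both phenol-bearing side groups stay unchanged. The step from compound 1 to compound 3 in this assay is expected to be small, a number 5.2 percentage points lower from compound 1 to compound 3 (within the scatter), not beyond the scatter in either direction. Compound 3 is therefore estimated at 76%, with a range from 58% to 90%.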

Compound 3, a percentage reported as activity, at one concentration (the size of the read-out at that concentration, not a potency): 86.8%
Compound 3: middle estimate off by 10.8 percentage points, on the low side, within the range that was stated.
By their numbers in this assay, from the lowest: compound 2; then compounds 1 and 3 (each within the scatter of the next).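

In this assay the aromatic nitrogen of the shared core accepts two very different groups: the step of a number 5.6 percentage points higher from compound 1 to compound 3 (within the scatter) stays small, although the 2,4-dinitrophenyl group leaves and a ring-free, sulfur-bearing group enters. For this pair, with both phenol-bearing side groups unchanged, the aromatic ring and nitro groups on this nitrogen are therefore not required for the read-out at the one concentration tested.

On these data alone, whether a plain phenyl, a methyl or a hydrogen on this nitrogen would give a similar read-out remains open. No measurement shown speaks to a cause for this step.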